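Enantiomer Swap at the Chain Stereocentre and Cytotoxicity

The source may report more compounds than this note shows. Statements on the series, on what has been measured and on what is new or still open speak of the compounds shown alone.

Measured so far:
Compound 1 `CCCC[C@@H](CCn1cncn1)c1ccc(Cl)cc1Cl` gives 1.9 ug/mL in an ADME assay on RD cells (Homo sapiens) for cytotoxicity, read by MTT assay, with a stated time of 3 days; on this read-out lower numbers stand for higher toxicity in this test and higher numbers for lower toxicity in this test.
Compound 2 `Clc1ccc([C@H](CCn2cncn2)Cc2ccccc2)cc1` gives 21.7 ug/mL in this assay.
Compound 3 `Clc1ccc([C@@H](CCn2cncn2)Cc2ccccc2)c(Cl)c1` gives 6.5 ug/mL in this assay.

Among the three measured compounds, compound 3 stands second highest in this assay. Its nearest neighbour is compound 2, whose number is higher by a gap beyond the scatter, and its furthest is compound 1, whose number is lower by a gap also beyond the scatter. Within the data shown here, no step between two measured compounds that differ in a single place is available, so none of these gaps can be tied to one structural change.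

Compound 4 `Clc1ccc([C@H](CCn2cncn2)Cc2ccccc2)c(Cl)c1` differs from compound 3 as follows: the two compounds have the same atoms and bonds and differ only in configuration as drawn: 1 of 1 stereo elements differ; a stereocentre at a saturated chain carbon is drawn R in compound 3 and S in compound 4. Among the measured compounds shown here, with no measured pair in this set that differs only in configuration, there is no precedent here for the size or direction of such a step. The expectation is therefore that the step from compound 3 to compound 4, no change at the digits printed from compound 3 to compound 4 (within the scatter), stays within the scatter of this test. Compound 4 is expected to give about 6.5 ug/mL in this assay, with a range from 2.5 ug/mL to 17 ug/mL.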

Compound 4, half-maximal cytotoxic concentration: 1.9 ug/mL
Compound 4: middle estimate off by 3.4-fold (0.53 log units), on the high side, and the stated range ends above it.
By their numbers in this assay, from the lowest: compounds 1 and 4 (each within the scatter of the next); then compound 3; then compound 2.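

In this assay, the stereocentre at the saturated chain carbon matters on its own: drawing it S rather than R gives a 3.4-fold lower number from compound 3 to compound 4 (0.53 log units; beyond the scatter), and this step can be ascribed to configuration alone because nothing else separates the pair: the fact that compounds 3 and 4 differ only in the configuration as drawn. Chloro in place of hydrogen on an aromatic carbon gives the largest step of the set, an 11-fold lower number from compound 2 to compound 4 (1.06 log units; beyond the scatter). By contrast, phenyl in place of propyl on a saturated chain carbon, two bonds along the chain from an aromatic carbon, gives no change at the digits printed from compound 1 to compound 4 (within the scatter).

The compounds shown leave open whether the configuration step keeps its direction and size with the propyl-bearing chain or with a single chloro on the ring. They also leave open how a fluoro or methoxy group on that ring, or an amine on the chain, would shift the number.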